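Swapping a pyridinyl arm for a substituted benzyl on a shared core

A few compounds are considered here, and "the series" means these few. Any claim that something is new, unique, unknown or untested is made for them only; others in the source may bear on it.

The compounds here share one core and differ only in the group attached through a saturated chain carbon to the amine nitrogen in a ring. Compound 1 is `O=c1c2cnn(-c3ccc(F)cc3)c2ncn1CC1(O)CCN(Cc2cccnc2)CC1`; in an assay on Sf21 cells for inhibition of ubiquitin carboxyl-terminal hydrolase 7 (Homo sapiens), read by spectrophotometry, with stated times of 30 min and 2 h (a higher number here means a weaker inhibitor, a lower number a stronger inhibitor), compound 1 is recorded as "not determined" (no result reported), so compound 1 has no measured standing of its own. Compound 2 is `O=c1c2cnn(-c3ccc(F)cc3)c2ncn1CC1(O)CCN(Cc2ccncc2)CC1`, and in this assay compound 2 likewise stands at "not determined" (no result reported). Among the measured compounds shown here, the only measured member of the set is compound 3, `N#Cc1ccccc1CN1CCC(O)(Cn2cnc3c(cnn3-c3ccc(F)cc3)c2=O)CC1`, which in this assay gives 8100 nM, a weak result. Compound 4, `COC(=O)c1ccc(CN2CCC(O)(Cn3cnc4c(cnn4-c4ccc(F)cc4)c3=O)CC2)c(Cl)c1`, is the compound yet to be tested. Compared with compound 1, it carries the change (2-chloro-4-(methoxycarbonyl)phenyl in place of pyridin-3-yl on a saturated chain carbon bound to an amine nitrogen in a ring). For the measured compounds named here, no measured pair in this set shows what such a change does, so the direction cannot be read from the data; the only anchor is compound 3, whose own aryl arm also lacks a ring nitrogen and sits in the weak range. On that basis compound 4 is expected to land in a similar weak region rather than to show a step clearly beyond the scatter in either direction. The estimate for compound 4 in this assay is 6000 nM, with a plausible range from 1500 nM to 25000 nM.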

Compound 4, half-maximal inhibitory concentration: 800 nM
For compound 4 the middle estimate is 7.5-fold (0.88 log units) above the measured one; the whole stated range lies above it.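

In this assay, the aryl group on a saturated chain carbon bound to an amine nitrogen in a ring proves able to shift the reading on its own: putting 2-chloro-4-(methoxycarbonyl)phenyl in place of 2-cyanophenyl gives a 10-fold lower number from compound 3 to compound 4 (1.01 log units; beyond the scatter), a large step beyond the usual scatter. Until now the set held a single number, so it could not show whether this arm mattered at all; with the shared core held constant, this pair shows that it does, and that compound 4 at 800 nM is the stronger of the two compounds with a number. Nothing measured here explains why the step occurs.

Steps involving compound 1 or compound 2 cannot be read, so how a pyridinyl arm compares with either substituted phenyl arm stays unknown. The entering group also differs from 2-cyanophenyl in two features at once, so this pair cannot divide the gain between the chlorine and the methoxycarbonyl group; a plain 2-chlorophenyl arm, or a carboxylic acid in place of the methyl ester, would be the kind of comparison needed to separate them.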